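A few compounds are considered here, and "the series" means these few. Any claim that something is new, unique, unknown or untested is made for them only; others in the source may bear on it.

Working notes on the series. Compound 1 `C=CCn1c(=O)/c(=C\c2cccc(Cl)c2Cl)[nH]c(=O)/c1=C\c1ccccc1OC` carries a 2,3-dichlorophenyl group on one side of the shared core; in a functional assay on HL-60 cells (Homo sapiens) for cytotoxicity, read by CCK-8 assay, with a stated time of 72 h (on this read-out higher numbers stand for weaker inhibition and lower numbers for stronger inhibition), compound 1 gives 2000 nM. Compound 2 `C=CCn1c(=O)/c(=C\c2ccc(Cl)c(Cl)c2)[nH]c(=O)/c1=C\c1ccccc1OC` differs from compound 1 only in the arrangement of the two chlorines on that ring, and in this assay compound 2 is reported as "not active" (no number reported), with no number attached. Among the compounds with values here, compound 2 therefore stands with no measured value, and no step to compound 1 can be sized from the data. Compound 3 `C=CCn1c(=O)/c(=C\c2cc(Br)ccc2F)[nH]c(=O)/c1=C\c1ccccc1OC` is not yet measured; it differs from compound 2 by 5-bromo-2-fluorophenyl in place of 3,4-dichlorophenyl on a double-bonded chain carbon bound to an aromatic carbon. Within the data shown here, no step between measured compounds is available for this change, so the direction is open; since compound 2 has no number, the expectation for compound 3 rests on compound 1 and the general level of the series. Compound 3 is estimated at 6000 nM in this assay, within a range from 1200 nM to 30000 nM, with a real chance that only a limit is reported.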

Compound 3, half-maximal inhibitory concentration: 17400 nM
For compound 3 the middle estimate is 2.9-fold (0.46 log units) below the measured one; the measured number falls inside the stated range.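

In this assay, within the data shown here, the exchange of one halogenated phenyl group for the other gives an 8.7-fold higher number from compound 1 to compound 3 (0.94 log units; beyond the scatter) and so provides the first sized step at this position, one beyond the scatter and toward weaker inhibition. The group leaving and the group entering match in what is counted for them and differ only in their halogens and the arrangement of those halogens. Compound 2 has no number, so steps involving it cannot be read.

On these data alone, both halogens change at once, so the share of each in the step stays unresolved, and the reading of a plain phenyl, or of a phenyl bearing an amine or a carboxylic acid, at this carbon remains open. No evidence bearing on the cause of this step is available.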